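The compounds below may be only part of what the source reports. "The series", "measured", "known", "first", "only" and "open" are said of these compounds alone.

Measured in an ADME assay on microsomes from liver (Homo sapiens) for metabolic stability, read by LC-MS, with a stated time of 10 min, tested at 0.5 uM; on this read-out higher numbers stand for a more stable compound and lower numbers for a less stable compound:
- compound 1 `c1ccc2c(c1)CN[C@@H](CN(CC1CCNCC1)[C@H]1CCCc3cccnc31)C2`: 86%
- compound 2 `c1ccc2c(c1)CN[C@H](CN(CCCN1CCNCC1)[C@H]1CCCc3cccnc31)C2`: 99%
- compound 3 `c1ccc2c(c1)CN[C@@H](CN(CC[C@@H]1CCCNC1)[C@H]1CCCc3cccnc31)C2`: 75%

Compound 1 stands second of these three numbers, with compound 3 lower at 75% and compound 2 higher at 99%.

The next compound is compound 4 `NC(=O)N1CCN(CCCN(C[C@H]2Cc3ccccc3CN2)[C@H]2CCCc3cccnc32)CC1`, not yet measured. Its change from compound 1 is a group of 11 heavy atoms (7 carbon, 3 nitrogen, 1 oxygen; one six-membered non-aromatic ring with 2 hetero atoms) in place of a group of 6 heavy atoms (5 carbon, 1 nitrogen; one six-membered non-aromatic ring with 1 hetero atom), on a saturated chain carbon bound to an amine nitrogen. The group that leaves is piperidin-4-yl, and the group that enters is larger and carries a double bond outside aromatic rings.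

Going by the values given here, only one measured step changes this same place: a number 11 percentage points lower from compound 1 to compound 3 (beyond the scatter), a modest drop. It involves a much smaller swap, so it sets only a rough scale. Among the compounds with values here, compound 2, with the side chain nearest to the entering group, gives 99%, which hints at a small rise, although no measured step covers this exact change.

The expected change is a number 4 percentage points higher from compound 1 to compound 4 (within the scatter), so no clear step beyond the scatter is expected in this assay. The estimated value for compound 4 is 90%, with an expected range from 77% to 100%.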

Compound 4, percent of the compound remaining: 79%
Compound 4: middle estimate off by 11 percentage points, on the high side, and the stated range covers the measured number.
By their numbers in this assay, from the lowest: compounds 3, 4 and 1 (each within the scatter of the next, the first and the last beyond it); then compound 2.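

In this assay this position takes the group of 11 heavy atoms in place of piperidin-4-yl with a number 7 percentage points lower from compound 1 to compound 4 (within the scatter), so the much larger side chain brings no clear change in the read-out. Set against the piperidin-3-yl side chain, the reading is a number 4 percentage points higher from compound 3 to compound 4 (within the scatter), which puts the new side chain within the scatter of both earlier neighbours, even though those two stand apart by a number 11 percentage points lower from compound 1 to compound 3 (beyond the scatter) on the same scale. Nothing measured here explains why these numbers fall as they do.

On these data alone, whether the carbamoyl group on its own moves this number stays open. Also open, as far as these compounds go, is how an acetyl group on the piperazine nitrogen, a morpholine ring or a shorter chain at this position would read in this assay, and whether any of them would stand apart from these side chains.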